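Swapping a Nitrile-Bearing Ring for Naphthalene: Cytotoxicity Outlook

The source may report more compounds than this note shows. Statements on the series, on what has been measured and on what is new or still open speak of the compounds shown alone.

Three compounds have been tested in a functional assay on MRC5 cells (Homo sapiens); on this read-out lower numbers stand for higher toxicity in this test and higher numbers for lower toxicity in this test:

Compound 1 `N#Cc1ccc(CN2c3ccccc3C(=O)N(Cc3ccccc3)S2(=O)=O)cc1` gives 62000 nM
Compound 2 `O=S1(=O)N=C(OCc2ccccc2-c2ccccc2)c2ccccc2N1Cc1ccccc1-c1ccccc1` gives 47000 nM
Compound 3 `O=S1(=O)N=C(OCc2ccc(Cl)c(Cl)c2)c2ccccc2N1Cc1ccc(Cl)c(Cl)c1` gives 48000 nM

Compound 1 has the highest number of the three in this assay, but its gaps to compound 3 and to compound 2 both lie within the scatter, so the three cannot be put in order; all three are weakly toxic on this cell line.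

Compound 4 `O=C1c2ccccc2N(Cc2cccc3ccccc23)S(=O)(=O)N1Cc1ccccc1` differs from compound 1 in one place: naphthalen-1-yl in place of 4-cyanophenyl on a saturated chain carbon bound to a sulfonamide nitrogen in a ring. For the measured compounds named here, no pair of measured compounds shows the effect of such a swap, so the only guide is that every measured compound sits at a similar, weak level. The step from compound 1 to compound 4 in this assay is expected to be small, a 1.4-fold lower number from compound 1 to compound 4 (0.14 log units; within the scatter), not beyond the scatter. Compound 4 is therefore estimated at 45000 nM, with a range from 20000 nM to 100000 nM.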

Compound 4, half-maximal cytotoxic concentration: > 58000 nM
Compound 4 gave a limit, no number (the forecaster's own chance of this, stated with the estimate: 10%); middle value at least 1.2-fold (0.11 log units) from the limit.
By their numbers in this assay, from the lowest: compounds 2, 3 and 1 (each within the scatter of the next).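

In this assay compound 4 gives > 58000 nM, which is a limit and not a number, so the step between compound 1 and compound 4 cannot be read. On these data alone, whether naphthalen-1-yl in place of 4-cyanophenyl changes the read-out at all stays open.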